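Urea Inhibitors: Swapping Nitrophenyl for Hydroxymethylphenyl

A few compounds are considered here, and "the series" means these few. Any claim that something is new, unique, unknown or untested is made for them only; others in the source may bear on it.

Compound 1 `Cc1ccc(C2(CNC(=O)Nc3c(C(C)C)cccc3C(C)C)CCCC2)cc1`: 25 nM
Compound 2 `CC(C)c1cccc(C(C)C)c1NC(=O)NCC1(c2ccc(Cl)cc2)CCCC1`: 32 nM
Compound 3 `CC(C)c1cccc(C(C)C)c1NC(=O)NCC1(c2ccc([N+](=O)[O-])cc2)CCCC1`: 131 nM

All three compounds share one core and differ only in the group carried on the aromatic ring that sits on the saturated five-membered ring. In an assay on microsomes for inhibition of acyl-CoA:cholesterol acyltransferase (Oryctolagus cuniculus) (on this read-out lower numbers stand for stronger inhibition and higher numbers for weaker inhibition), compound 3 stands highest of the three numbers, that is, it is the weakest inhibitor here: a 5.2-fold higher number from compound 1 to compound 3 (0.72 log units; beyond the scatter) and a 4.1-fold higher number from compound 2 to compound 3 (0.61 log units; beyond the scatter), both beyond the scatter, whereas a 1.3-fold higher number from compound 1 to compound 2 (0.11 log units; within the scatter).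

Compound 4 `CC(C)c1cccc(C(C)C)c1NC(=O)NCC1(c2cccc(CO)c2)CCCC1` is the next compound. Its change from compound 3 is 3-(hydroxymethyl)phenyl in place of 4-nitrophenyl on a saturated ring carbon. For the measured compounds named here, the steps that bear on this are the two that involve the nitro group: in each, the compound carrying 4-nitrophenyl gave a modestly higher number than its partner with methyl or chloro. Removing the nitro group is therefore expected to lower the number again. Going by the values given here, no measured compound carries a hydroxymethyl group, so the size of the effect is uncertain and the range is kept wide.

Compound 4 is expected to give about 60 nM in this assay, most likely between 20 nM and 200 nM. This estimate corresponds to an expected 2.2-fold lower number from compound 3 to compound 4 (0.34 log units; beyond the scatter).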

Compound 4, half-maximal inhibitory concentration: 15 nM
For compound 4 the middle estimate is 4.0-fold (0.60 log units) above the measured one; measured number below the stated range.
By their numbers in this assay, from the lowest: compounds 4, 1 and 2 (each within the scatter of the next, the first and the last beyond it); then compound 3.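

In this assay, 3-(hydroxymethyl)phenyl in place of 4-nitrophenyl gives an 8.7-fold lower number from compound 3 to compound 4 (0.94 log units; beyond the scatter), and in place of 4-chlorophenyl it gives a 2.1-fold lower number from compound 2 to compound 4 (0.33 log units; beyond the scatter), while the change from 4-methylphenyl gives a 1.7-fold lower number from compound 1 to compound 4 (0.22 log units; within the scatter), which stays within the scatter. The earlier compounds shown here showed only how three groups compare when each is carried as a 4-substituted phenyl; this result shows that the saturated ring carbon can also carry 3-(hydroxymethyl)phenyl, with 1 hydrogen-bond donor, and keep a number level with the best of those earlier compounds, compound 1. Nothing available here explains why the number moves as it does with this change.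

Each of these steps alters both the group and its place on the aromatic ring, so the compounds shown cannot say how much of the effect belongs to the hydroxymethyl group and how much to its place, a question that 4-(hydroxymethyl)phenyl and 3-methylphenyl would help to settle. On these data alone, it also remains open whether a longer chain ending in a hydroxyl, an amine or a carboxylic acid would be accepted here as well.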